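Methyl on the Aromatic Ring in Two Triazole Cores

A few compounds are considered here, and "the series" means these few. Any claim that something is new, unique, unknown or untested is made for them only; others in the source may bear on it.

Compound 1 `c1ccc(C[C@@H](CCn2cncn2)c2ccccc2)cc1` was examined in an ADME assay on HEp-2 cells (Homo sapiens) for cytotoxicity, read by MTT assay, with a stated time of 3 days (on this read-out higher numbers stand for lower toxicity in this test and lower numbers for higher toxicity in this test), where compound 1 gives 55.9 ug/mL. Compound 2 `Cc1ccc([C@H](CCn2cncn2)Cc2ccccc2)cc1` differs from it by methyl in place of hydrogen on an aromatic carbon; in this assay compound 2 gives 152 ug/mL, a step of a 2.7-fold higher number from compound 1 to compound 2 (0.43 log units; beyond the scatter). Compound 3 `c1ccc([C@@H](CCn2cncn2)C2CCCCC2)cc1` carries a different core, and the difference between the two cores is not broken down here. In this assay compound 3 gives 21.8 ug/mL, the lowest of the three numbers. Compound 4 `Cc1ccc([C@@H](CCn2cncn2)C2CCCCC2)cc1` has not been measured; it differs from compound 3 by methyl in place of hydrogen on an aromatic carbon, the same change as that between compound 1 and compound 2, at the same place. The step is expected to be a 2.4-fold higher number from compound 3 to compound 4 (0.38 log units; beyond the scatter), because a 2.7-fold higher number from compound 1 to compound 2 (0.43 log units; beyond the scatter) was modest and beyond the scatter. Compound 4 is therefore estimated at 52 ug/mL, with a likely range from 25 ug/mL to 110 ug/mL.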

Compound 4, half-maximal cytotoxic concentration: 57.3 ug/mL
Estimate against measurement, compound 4: 1.1-fold (0.04 log units) below, and the stated range covers the measured number.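

In this assay, methyl in place of hydrogen on the aromatic carbon gave a 2.6-fold higher number from compound 3 to compound 4 (0.42 log units; beyond the scatter). The change therefore carried from the core of compound 1 to the core of compound 3 at much the same size, and the two steps do not differ: the same change on two cores in this assay, a 2.7-fold higher number (0.43 log units; beyond the scatter) from compound 1 to compound 2 and a 2.6-fold higher number (0.42 log units; beyond the scatter) from compound 3 to compound 4, 1.0-fold (0.01 log units) apart, within the scatter of two such steps. This shows agreement on two cores in this assay only; it does not show that the step would hold on any further core, nor does it explain why the number rises.

The compounds shown leave open whether an ethyl, a chlorine or a methoxy group in that place would behave as the methyl does on both cores. The same question stands for an amine or a carboxylic acid.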